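The source may hold more compounds than are shown below. What is called first, only, known or untested is meant among the compounds shown, and "the series" means these compounds.

Within the data shown here, in a functional assay on the whole organism (strain Kunming) with Mus musculus as the target, with a stated time of 0.5 h (on this read-out lower numbers stand for an effect already at smaller amounts and higher numbers for an effect only at larger amounts of compound), compound 1 (`COc1ccccc1/C=C/C(=O)OC/C=C/c1cc(OC)c(OC)cc1OC`) gives 780 umol/kg, the only actual number among the compounds measured so far. Compound 2 (`COc1cc(OC)c(OC)cc1/C=C/COC(=O)/C=C/c1c(OC)ccc(OC)c1OC`) is reported only as a limit, > 674 umol/kg. Compound 3 (`COc1cc(OC)c(OC)cc1/C=C/COC(=O)/C=C/c1cc(OC)c(OC)c(OC)c1`) is also reported only as a limit, > 450 umol/kg. Compound 4 (`COc1cc(OC)c(OC)cc1/C=C/COC(=O)/C=C/c1ccccc1Cl`) has not yet been measured and differs from compound 1 in one place: chloro in place of methoxy on an aromatic carbon. Put simply, the 2-methoxyphenyl of compound 1 becomes 2-chlorophenyl in compound 4. Among the measured compounds shown here, no measured pair shows this change, so no step beyond the scatter is expected in this assay, in either direction. For compound 4 the estimate is 650 umol/kg, with an expected range of 280 umol/kg to 1500 umol/kg. The expected step of a 1.2-fold lower number from compound 1 to compound 4 (0.08 log units; within the scatter) is therefore small.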

Compound 4, dose for half-maximal effect: 639 umol/kg
Compound 4: middle estimate off by 1.0-fold (0.01 log units), on the high side; low and high end bracket the measured number.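

In this assay, among these compounds, the change from 2-methoxyphenyl to 2-chlorophenyl gives the first readable step at this position, a 1.2-fold lower number from compound 1 to compound 4 (0.09 log units; within the scatter). Here a methoxy, counted with a hydrogen-bond acceptor, gives way to a chloro, counted with none, and the dose stays within the scatter. No measurement shown bears on why the two groups read alike. From the compounds shown here alone, an amine, a carboxylic acid or a longer chain on this aromatic carbon remains open. So does whether any group here can move the dose beyond the scatter.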